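Expected Cytotoxicity After Replacing the Arm on Compound 3

The compounds below may be only part of what the source reports. "The series", "measured", "known", "first", "only" and "open" are said of these compounds alone.

Three measured compounds share one core and differ only in the group on a double-bonded chain carbon. Compound 1 `COc1cc(NC(C)CCCNC(=O)NNC(=O)/C=C/c2ccc(OC)c(OC)c2)c2ncccc2c1` gives 37000 nM in an ADME assay on L6 cells (Rattus norvegicus) for cytotoxicity, read by resazurin assay, with a stated time of 70 h; on this read-out higher numbers stand for weaker inhibition and lower numbers for stronger inhibition. Compound 2 `COc1cc(NC(C)CCCNC(=O)NNC(=O)/C=C/c2ccccc2F)c2ncccc2c1` gives 25100 nM. Compound 3 `COc1cc(NC(C)CCCNC(=O)NNC(=O)/C=C/c2ccc(C(F)(F)F)cc2)c2ncccc2c1` gives 28300 nM, the second highest of the three numbers; its nearest is compound 2 and its furthest is compound 1, both within the scatter. The measured steps were a 1.5-fold lower number from compound 1 to compound 2 (0.17 log units; within the scatter), a 1.3-fold lower number from compound 1 to compound 3 (0.12 log units; within the scatter) and a 1.1-fold higher number from compound 2 to compound 3 (0.05 log units; within the scatter). Compound 4 `COc1cc(NC(C)CCCNC(=O)NNC(=O)Nc2ccc(Br)cc2)c2ncccc2c1` differs from compound 3 by (4-bromophenyl)amino in place of 2-(4-(trifluoromethyl)phenyl)ethenyl on a carbonyl carbon. For the measured compounds named here, no measured step touches this carbonyl carbon, so the three steps bear on it only loosely; all stayed within the scatter, and no step beyond the scatter is expected in this assay. For compound 4 the expected value is 28000 nM, with a range from 12000 nM to 65000 nM. The expected step is therefore a 1.0-fold lower number from compound 3 to compound 4 (0.00 log units; within the scatter).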

Compound 4, half-maximal inhibitory concentration: 38700 nM
Beside the measured number, compound 4's estimate is 1.4-fold (0.14 log units) below it; the measured number falls inside the stated range.
By their numbers in this assay, from the lowest: compounds 2, 3, 1 and 4 (each within the scatter of the next).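

Until now only the ring group on the ethenyl arm had varied. Compound 4 shows that in this assay the whole arm on this carbonyl carbon can be exchanged for (4-bromophenyl)amino, which brings a nitrogen and a hydrogen-bond donor and removes the double bond outside the ring, with all three steps within the scatter: a 1.4-fold higher number from compound 3 to compound 4 (0.14 log units; within the scatter) and a 1.5-fold higher number from compound 2 to compound 4 (0.19 log units; within the scatter) and a 1.0-fold higher number from compound 1 to compound 4 (0.02 log units; within the scatter). No supporting evidence is available to interpret this result.

Still open, on these data alone, is whether a plain amine or a longer chain ending in a carboxylic acid on this carbonyl carbon would give a step beyond the scatter. The role of the bromine also remains open, with (4-bromophenyl)amino the only amino arm shown.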